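Compound 3: Cyclohexyl in Place of Phenyl on Nitrogen

The source may hold more compounds than are shown below. What is called first, only, known or untested is meant among the compounds shown, and "the series" means these compounds.

Among the two measured compounds, compound 2 `O=c1cc(Nc2ccccc2)cc(-c2ccccc2)o1` gives the lowest number: in a functional assay on DU-145 cells (Homo sapiens) for cytotoxicity, read by MTT assay, with a stated time of 72 h (on this read-out higher numbers stand for an effect only at larger amounts of compound and lower numbers for an effect already at smaller amounts), compound 2 gives 0.098 uM. Compound 1 `COc1cccc(Nc2cc(-c3ccccc3)oc(=O)c2)c1`, which carries a methoxy on the aromatic ring attached to the nitrogen, gives 0.66 uM in this assay, and the step of a 6.7-fold lower number from compound 1 to compound 2 (0.83 log units; beyond the scatter). Compound 3 `O=c1cc(NC2CCCCC2)cc(-c2ccccc2)o1` differs from compound 2 by cyclohexyl in place of phenyl on a nitrogen on an aromatic ring. Within the data shown here, no measured step exchanges an aromatic ring for a saturated one at this position; the single measured step, which links compound 1 and compound 2, concerns a substituent on the phenyl that now leaves, so it bears on the new change only by showing that this part of the molecule responds to alteration. A step beyond the scatter in either direction therefore cannot be excluded, and the expectation is a modest rise, a 3.1-fold higher number from compound 2 to compound 3 (0.49 log units; beyond the scatter). Compound 3 is estimated at 0.3 uM, within the range 0.08 uM to 1.5 uM.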

Compound 3, concentration for half-maximal effect: 7.47 uM
Beside the measured number, compound 3's estimate is 25-fold (1.40 log units) below it, outside the stated range (above it).
By their numbers in this assay, from the lowest: compound 2; then compound 1; then compound 3.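

In this assay, among these compounds, the change gives a 76-fold higher number from compound 2 to compound 3 (1.88 log units; beyond the scatter), a large step, whereas the only earlier step at this part of the molecule, a 6.7-fold lower number from compound 1 to compound 2 (0.83 log units; beyond the scatter), is modest and concerns a substituent on the phenyl. The position therefore responds strongly to the ring on the nitrogen itself: phenyl and cyclohexyl have the same counts of heavy atoms, hydrogen-bond donors and hydrogen-bond acceptors, yet the aromatic ring goes with the far lower number. No measurement at hand explains this difference.

The compounds shown leave open whether a pyridine ring or a benzyl group on the nitrogen would keep a number close to that of compound 2. They also leave open how a fluorine or a hydroxyl on the phenyl would compare with the methoxy of compound 1.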